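The source may report more compounds than this note shows. Statements on the series, on what has been measured and on what is new or still open speak of the compounds shown alone.

Among the compounds with values here, compound 1 `CN1CCC(C(=O)N2Cc3c(NC(=O)c4ccsc4)n[nH]c3C2(C)C)CC1` is measured in a functional assay on A2780 cells (Homo sapiens) for antiproliferative activity, read by fluorescence, with a stated time of 72 h (a higher number here means a weaker inhibitor, a lower number a stronger inhibitor), where compound 1 gives 140 nM, the lowest of the three numbers known. Compound 3 `CCN1CCC(C(=O)N2Cc3c(NC(=O)c4ccc(F)cc4)n[nH]c3C2(C)C)CC1` gives 290 nM, and compound 2 `CC(C)CC(=O)Nc1n[nH]c2c1CN(C(=O)C1CCN(C3CC3)CC1)C2(C)C` gives 320 nM; both of these differences from compound 1 lie beyond the usual scatter, so compound 1 stands as the strongest inhibitor of the three. Compound 4 `CN1CCC(C(=O)N2Cc3c(NC(=O)c4ccc5ccccc5c4)n[nH]c3C2(C)C)CC1` shares the core of compound 1, and differs from compound 1 in a single place: naphthalen-2-yl in place of thiophen-3-yl on a carbonyl carbon. Within the data shown here, no two measured compounds are separated by a single change of this kind. The step expected in this assay from this change is a 1.8-fold higher number from compound 1 to compound 4 (0.25 log units; within the scatter), toward a slightly weaker inhibitor but close to the scatter. Compound 4 is therefore estimated at 250 nM, within a range from 80 nM to 800 nM.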

Compound 4, half-maximal inhibitory concentration: 270 nM
Beside the measured number, compound 4's estimate is 1.1-fold (0.03 log units) below it; the measured number falls inside the stated range.
By their numbers in this assay, from the lowest: compounds 1, 4, 3 and 2 (each within the scatter of the next, the first and the last beyond it).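

Replacing thiophen-3-yl with naphthalen-2-yl on a carbonyl carbon whose other neighbour is an amide-type nitrogen gives a 1.9-fold higher number from compound 1 to compound 4 (0.29 log units; within the scatter) in this assay. Within the data shown here, this is the first pair of compounds here that differ in one place, and it shows that two six-membered aromatic rings of carbon only can stand where one five-membered aromatic ring with a sulfur stood, with no change beyond the scatter. How an amine or a carboxylic acid at this place would read remains open, and no measurement shown explains the result.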